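Inverting two ring stereocentres: an expected cytotoxicity reading

A few compounds are considered here, and "the series" means these few. Any claim that something is new, unique, unknown or untested is made for them only; others in the source may bear on it.

In a functional assay on FL5.12 cells (Mus musculus) for cytotoxicity, read by flow cytometry and propidium iodide staining, with a stated time of 48 h (a lower number here means a stronger inhibitor, a higher number a weaker inhibitor), compound 1 (`CCCCCCCCc1ccc(CC[C@@H]2CCCN2)cc1`) gives 2800 nM and compound 2 (`CCCCCCCCc1ccc(CC(O)[C@@H]2C[C@@H](O)CN2)cc1`) gives 3000 nM as its reading. These two numbers lie within the usual scatter of repeat measurements, so compound 2 stands level with compound 1.

Compound 3 (`CCCCCCCCc1ccc(CC(O)[C@H]2C[C@H](O)CN2)cc1`) has the same atoms and bonds as compound 2 and differs only in spatial arrangement (the two compounds have the same atoms and bonds; at least one stereo element is drawn with a configuration in one of them and without one in the other: 2 of 3 stereo elements differ; a stereocentre at a saturated ring carbon is drawn S in compound 2 and R in compound 3; a stereocentre at a saturated ring carbon is drawn R in compound 2 and S in compound 3), so this is a change of stereochemistry alone. One stereocentre at a saturated ring carbon is drawn S in compound 2 and R in compound 3, and another is drawn R in compound 2 and S in compound 3.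

Among the measured compounds shown here, no measured pair yet shows what such a swap does in this assay so the only anchor is compound 2 at 3000 nM as the starting point. The expected change is no change at the digits printed from compound 2 to compound 3 (within the scatter) with no favoured direction and nothing beyond the scatter. Compound 3 is estimated at 3000 nM with an expected range of 1400 nM to 6500 nM once it is measured.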

Compound 3, half-maximal inhibitory concentration: 1800 nM
Compound 3: the middle estimate sits 1.7-fold (0.22 log units) above what was measured, within the range that was stated.
By their numbers in this assay, from the lowest: compounds 3, 1 and 2 (each within the scatter of the next).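

In this assay, inverting the two stereocentres at saturated ring carbons gives a 1.7-fold lower number from compound 2 to compound 3 (0.22 log units; within the scatter), the first measured swap of this kind among these compounds. This assay therefore does not separate these two spatial arrangements of the same atoms and bonds, so here the pair of ring configurations makes no difference that can be read beyond ordinary repeat variation. One caution applies to treating them as two fully defined arrangements: the fact that one of compounds 2 and 3 is drawn with a defined configuration and the other without, at the place where they differ

As far as these compounds go, both ring stereocentres change together in this pair, so what either inversion does alone remains open. It is also unknown whether the same insensitivity would hold with an amine or a carboxylic acid in place of the ring hydroxyl group, or with a longer chain on the shared core.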